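Cyclic sulfonamide series: tolerance on cells, step to compound 4

The source may hold more compounds than are shown below. What is called first, only, known or untested is meant among the compounds shown, and "the series" means these compounds.

The shared core of compound 1 `O=C1c2ccccc2N(COCc2ccccc2)S(=O)(=O)N1Cc1ccccc1` carries two substituted saturated chain carbons on the two ring nitrogens. In a functional assay on HEL cells (Homo sapiens) (a higher number here means that more compound is tolerated, a lower number that less compound is tolerated), compound 1 gives 122000 nM. Compound 3 `O=C1c2ccccc2N(Cc2ccc(Cl)c(Cl)c2)S(=O)(=O)N1Cc1ccccc1` bears a 3,4-dichlorophenyl where compound 1 has benzyloxy, and in this assay compound 3 gives 200000 nM; the step of a 1.6-fold higher number from compound 1 to compound 3 (0.21 log units; within the scatter). Compound 3 thus stands highest of the two numbers on hand, with compound 1 nearest and within the scatter of it. Compound 2 `O=C1c2ccccc2N(Cc2ccccc2Cl)S(=O)(=O)N1Cc1ccccc1Cl` is reported in this assay only as a limit, > 20000 nM, at which one of the three values sits (the limit of > 20000 nM in this assay, at which 1 of the 3 values shown sits).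

Compound 4 `O=C1c2ccccc2N(Cc2ccccc2Cl)S(=O)(=O)N1Cc1ccccc1` differs from compound 3 as follows: 2-chlorophenyl in place of 3,4-dichlorophenyl on a saturated chain carbon bound to a sulfonamide nitrogen in a ring. Among the compounds with values here, the only measured step at this position, the one from compound 1 to compound 3, lay within the scatter, and no other step bears on it. No change beyond the scatter is therefore expected, with the step of a 1.7-fold lower number from compound 3 to compound 4 (0.22 log units; within the scatter) as the expected size. For compound 4 the estimate in this assay is 120000 nM, with a range from 40000 nM to 300000 nM.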

Compound 4, minimum cytotoxic concentration: 200000 nM
The estimate for compound 4 lay 1.7-fold (0.22 log units) below the measured number, and the stated range covers the measured number.
By their numbers in this assay, from the lowest: compounds 1, 3 and 4 (each within the scatter of the next).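

In this assay, replacing 3,4-dichlorobenzyl with 2-chlorobenzyl gives no change at the digits printed from compound 3 to compound 4 (within the scatter), so this change does not separate the two groups. Replacing benzyloxy with 2-chlorophenyl on a saturated chain carbon bound to a sulfonamide nitrogen in a ring gives a 1.6-fold higher number from compound 1 to compound 4 (0.21 log units; within the scatter), so the three groups now seen at this position all lie within the scatter of one another. Compound 2 is held only as a limit, and the step from it, hydrogen in place of chloro on an aromatic carbon, cannot be read: the limit of > 20000 nM in this assay, at which 1 of the 4 values shown sits.

As far as these compounds go, whether chloro on the other benzyl group shifts the tolerated concentration therefore stays open. From the compounds shown here alone, it also stays open whether an amine, a carboxylic acid or a longer chain at this position would move the number beyond the scatter.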